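This account rests on a few compounds, and the source may have more. Where it says the series, first, only, none or still open, it means among the compounds named here.

Compound 1 `COc1ccc(/C=C/S(=O)(=O)Cc2ccc(OC)c([N+](=O)[O-])c2)cc1` and compound 2 `COc1ccc(/C=C/S(=O)(=O)Cc2ccc(OC)c(N)c2)cc1` share one core and differ in a single place: amino in place of nitro on an aromatic carbon. In a functional assay on K562 cells (Homo sapiens) for cytotoxicity, read by trypan blue exclusion, with a stated time of 96 h (on this read-out lower numbers stand for stronger inhibition and higher numbers for weaker inhibition), compound 1 gives 25000 nM, while compound 2 gives 2500 nM, so this change made a 10-fold lower number from compound 1 to compound 2 (1.00 log units; beyond the scatter). Compound 3 `COc1cc(OC)c(/C=C/SCc2ccc(OC)c([N+](=O)[O-])c2)c(OC)c1` is built on a different core, and the difference between the two cores is not broken down here. In this assay compound 3 gives 5000 nM. Compound 4 `COc1cc(OC)c(/C=C/SCc2ccc(OC)c(N)c2)c(OC)c1` has not been measured yet; it differs from compound 3 by the same change, (amino in place of nitro on an aromatic carbon), at the same place. Among the compounds with values here, because the earlier case gave a 10-fold lower number from compound 1 to compound 2 (1.00 log units; beyond the scatter), a step of an 8.3-fold lower number from compound 3 to compound 4 (0.92 log units; beyond the scatter) is expected here as well, taken slightly smaller since only one pair supports it. Compound 4 is therefore estimated at 600 nM in this assay.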

Compound 4, half-maximal inhibitory concentration: 30 nM
Estimate against measurement, compound 4: 20-fold (1.30 log units) above; the measured number lies below the stated range.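

In this assay amino in place of nitro again lowers the number, with a 170-fold lower number from compound 3 to compound 4 (2.22 log units; beyond the scatter) on the second core. Set beside the earlier case, the direction of the step carries over between the two cores, but its size does not: the same change on two cores in this assay, a 10-fold lower number (1.00 log units; beyond the scatter) from compound 1 to compound 2 and a 170-fold lower number (2.22 log units; beyond the scatter) from compound 3 to compound 4, 17-fold (1.22 log units) apart, beyond the scatter of two such steps. So the step measured on one core did not fix the size of the step on the other, yet two pairs alone do not show which part of the difference between the cores goes with the larger step, or how the change would behave on a further core.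

The compounds shown leave open whether the gap between the steps would hold for other groups at the same place, such as a hydroxyl, an acetamide or a dimethylamino group.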